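The source may hold more compounds than are shown below. What is called first, only, known or untested is meant among the compounds shown, and "the series" means these compounds.

Measured compounds:
- compound 3 `CN(C)c1ccc(/C=C2\S/C(=N\c3nc(-c4ccc(Cl)cc4)cs3)NC2=O)cc1`: 200 nM in a functional assay on HCT-116 cells (Homo sapiens) for cytotoxicity, read by MTT assay, with a stated time of 72 h; a lower number here means a stronger inhibitor, a higher number a weaker inhibitor
- compound 1 `O=C1CS/C(=N\c2csc(-c3ccc(Cl)cc3)c2)N1c1ccccc1`: "not determined" (no result reported) in this assay
- compound 2 `CN(C)c1ccc(N2C(=O)CS/C2=N\c2csc(-c3ccc(Cl)cc3)c2)cc1`: "not determined" (no result reported) in this assay

Working notes. Among the measured compounds shown here, the series has only one number in this assay so far: compound 3 gives 200 nM. Compound 1 gives "not determined" (no result reported) and compound 2 gives "not determined" (no result reported) in this assay; these two, which share the chlorophenyl-substituted thiazole but carry the aryl on the ring nitrogen rather than as an exocyclic benzylidene, have no number in this assay, so nothing can be said about how they compare with compound 3. Compound 3 is therefore neither the strongest nor the weakest of anything; it is simply the only data point.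

The next compound, compound 4 `Cc1ccc(/C=C2\S/C(=N\c3nc(-c4ccc(Cl)cc4)cs3)NC2=O)cc1`, keeps the whole of compound 3 apart from one change: methyl in place of dimethylamino on an aromatic carbon. For the measured compounds named here, no measured pair in this set maps this kind of replacement, so there is no step to lean on.

Expectation for compound 4: without a reference step, a modest shift is assumed, somewhat toward weaker inhibition, though a step within the scatter cannot be excluded. The estimated step from compound 3 is a 2.5-fold higher number from compound 3 to compound 4 (0.40 log units; beyond the scatter). On that basis compound 4 is expected to give about 500 nM in this assay, with a plausible range from 150 nM to 2000 nM.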

Compound 4, half-maximal inhibitory concentration: 500 nM
Beside the measured number, compound 4's estimate shows no gap at the digits printed, and the stated range covers the measured number.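

In this assay, among the compounds shown here, methyl in place of dimethylamino on the aromatic carbon para to a large group gives a 2.5-fold higher number from compound 3 to compound 4 (0.40 log units; beyond the scatter) and is the first step that can be read. The change therefore shows that this position affects the read-out, while the dimethylamino group is not essential for measurable cytotoxicity, as compound 4 still gives 500 nM in this assay with the rest of compound 3 intact. No measurement at hand addresses the origin of this step, so it remains an observation on a single pair.

From the compounds shown here alone, one pair sets no order among substituents, so it remains open where a methoxy group, a hydroxyl group, a carboxylic acid, a primary amine or a plain hydrogen in this place would fall relative to methyl and dimethylamino. Going by these compounds, it also remains open whether the same replacement would have a similar effect with the aryl group on the ring nitrogen, the arrangement found in compound 2.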